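The source may hold more compounds than are shown below. What is called first, only, known or untested is meant among the compounds shown, and "the series" means these compounds.

The compounds measured so far:

Compound 1, `CCOC(=O)c1cnc(C)nc1NN1C(=O)C=C(C)C1=O`: in a functional assay on Jurkat cells for inhibition of nuclear factor NF-kappa-B complex (Homo sapiens) (a lower number here means a stronger inhibitor, a higher number a weaker inhibitor), compound 1 gives 16000 nM.
Compound 2, `CCOC(=O)c1cnc(CC)nc1NN1C(=O)C=C(C)C1=O`: compound 2 gives 10000 nM.
Compound 3, `CCOC(=O)c1cnc(-c2ccc(Cl)cc2)nc1NN1C(=O)C=C(C)C1=O`: compound 3 gives 300 nM.

Compound 2 holds the second highest of the three numbers. Its nearest neighbour is compound 1, separated by a 1.6-fold lower number from compound 1 to compound 2 (0.20 log units; within the scatter), which lies within the scatter, so the two cannot be told apart. Compound 3 is far off, with a 33-fold lower number from compound 2 to compound 3 (1.52 log units; beyond the scatter).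

The unmeasured compound 4, `CCOC(=O)c1cnc(-c2cc3ccccc3s2)nc1NN1C(=O)C=C(C)C1=O`, differs from compound 2 in one place:

1-benzothiophen-2-yl in place of ethyl on an aromatic carbon

Going by the values given here, the step that bears most directly on this is the one from compound 2 to compound 3, where 4-chlorophenyl took the place of ethyl on the same aromatic carbon and gave a 33-fold lower number from compound 2 to compound 3 (1.52 log units; beyond the scatter). The parallel step from compound 1, a 53-fold lower number from compound 1 to compound 3 (1.73 log units; beyond the scatter), points the same way. Both show that an aromatic group on this carbon, in place of a short chain, goes with a large drop in the number. 1-benzothiophen-2-yl is likewise an aromatic group, so a large step downward in this assay is expected, of roughly the size already seen. Compound 4 is therefore estimated at 300 nM, with a range from 60 nM to 1500 nM. That estimate means an expected step of a 33-fold lower number from compound 2 to compound 4 (1.52 log units; beyond the scatter).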

Compound 4, half-maximal inhibitory concentration: 4000 nM
The estimate for compound 4 lay 13-fold (1.12 log units) below the measured number, outside the stated range (above it).
By their numbers in this assay, from the lowest: compound 3; then compound 4; then compounds 2 and 1 (each within the scatter of the next).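

In this assay, an aromatic group on this carbon between two ring nitrogen atoms does not by itself bring the large drop seen with 4-chlorophenyl: 1-benzothiophen-2-yl in place of ethyl gives only a 2.5-fold lower number from compound 2 to compound 4 (0.40 log units; beyond the scatter) and in place of methyl gives a 4.0-fold lower number from compound 1 to compound 4 (0.60 log units; beyond the scatter) as a similarly modest gain. Exchanging one aromatic group for the other gives a 13-fold higher number from compound 3 to compound 4 (1.12 log units; beyond the scatter) on the same core, so the identity of the aromatic group matters a great deal here, and the simple contrast between a short chain and an aromatic group no longer describes the series. The direction of that contrast still holds for all four compounds, since compound 3 and compound 4 both have lower numbers than compound 1 and compound 2, but its size ranges from modest to large.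

The compounds shown leave open whether a plain phenyl ring, a 4-methoxyphenyl group or an amine on this carbon would fall nearer to compound 3 or to compound 4. Nothing available here accounts for the wide gap between the two aromatic groups.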